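A Trifluoromethyl Replaces One Chlorine on the Urea Aryl

This account rests on a few compounds, and the source may have more. Where it says the series, first, only, none or still open, it means among the compounds named here.

Compound 2 `COc1cc(-c2nn(-c3cccc(NC(=O)Nc4ccc(Cl)c(Cl)c4)c3)cc2-c2ccncc2)ccc1Cl` carries a 3,4-dichlorophenyl on the urea of the shared core. In a functional assay on SNB-75 cells (Homo sapiens) for inhibition, read by sulforhodamine B assay, with a stated time of 48 h (a higher number here means that more compound is tolerated, a lower number that less compound is tolerated), compound 2 gives only a limit, > 50000 nM, so that among the three measured compounds it stands at the upper boundary the limit of > 50000 nM in this assay, at which 1 of the 3 values shown sits, rather than at a number. Compound 1 `COc1cc(-c2nn(-c3cccc(NC(=O)Nc4cc(C(F)(F)F)cc(C(F)(F)F)c4)c3)cc2-c2ccncc2)ccc1Cl`, which carries a bis(trifluoromethyl)phenyl on the same urea, gives 5310 nM in this assay. Compound 3 `O=C(Nc1cccc(-n2cc(-c3ccncc3)c(-c3ccc(Cl)c(O)c3)n2)c1)Nc1ccc(Cl)c(Cl)c1` differs from compound 2 by hydrogen in place of methyl on an oxygen on an aromatic ring; in this assay compound 3 also gives a limit, > 32500 nM. The step that the two limits leave unreadable from compound 2 to compound 3 therefore lies between two limits the limit of > 32500 nM in this assay, at which 1 of the 3 values shown sits, and cannot be read.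

Compound 4 `COc1cc(-c2nn(-c3cccc(NC(=O)Nc4ccc(Cl)c(C(F)(F)F)c4)c3)cc2-c2ccncc2)ccc1Cl` differs from compound 2 by trifluoromethyl in place of chloro on an aromatic carbon. Within the data shown here, no measured step bears directly on this change. Compound 1, bearing two trifluoromethyl groups, gives a number in this assay, while compound 2, bearing two chloro groups, gives a limit, and compound 4 holds one of each. Compound 4 is thus expected to fall between them, at about 20000 nM, with a range from 6000 nM to 80000 nM. The expected step is an at least 2.5-fold lower number from compound 2 to compound 4 (0.39 log units; beyond the scatter), toward a readable value, though a limit remains possible.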

Compound 4, concentration lethal to 50% of the cells: > 32500 nM
Compound 4 was reported as a limit (the forecaster's own chance of this, stated with the estimate: 40%); middle value at least 1.6-fold (0.21 log units) from the limit.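

In this assay compound 4 gives only a limit of > 32500 nM and no number. Among these compounds, compound 2 also stands at a limit, so no step between compound 2 and compound 4 can be read. The compounds shown leave open whether trifluoromethyl in place of chloro on this aromatic carbon changes the value in this assay at all.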